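A few compounds are considered here, and "the series" means these few. Any claim that something is new, unique, unknown or untested is made for them only; others in the source may bear on it.

Working notes on the hydroxyphenyl series.

Compound 3 `Oc1ccc(-c2cc(-c3ccccc3F)cc(-c3cccc(O)c3)n2)cc1` is the reference point. In a functional assay on HeLa cells (Homo sapiens) for inhibition (a lower number here means a stronger inhibitor, a higher number a weaker inhibitor), compound 3 gives 14300 nM. Of the two numbers shown this is the smaller, but compound 2 `Oc1cccc(-c2cc(-c3ccccc3F)cc(-c3cccc(O)c3)n2)c1` gives 16000 nM, a gap within the scatter, so no order between them is claimed. Compound 1 `Oc1ccc(-c2cc(-c3ccccc3F)cc(-c3ccccc3O)n2)cc1` returns only a limit in this assay, > 50000 nM, as recorded in the limit of > 50000 nM in this assay, at which 1 of the 3 values shown sits.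

Two measured steps lead into compound 3. an at least 3.4-fold lower number from compound 1 to compound 3 (0.54 log units; beyond the scatter) is beyond the scatter. a 1.1-fold lower number from compound 2 to compound 3 (0.05 log units; within the scatter) is within the scatter.

Compound 4 `Oc1ccc(-c2cc(-c3ccccc3F)cc(-c3ccc(O)cc3)n2)cc1` is not yet measured. It differs from compound 3 by 4-hydroxyphenyl in place of 3-hydroxyphenyl on an aromatic carbon. The same exchange of a 3-hydroxyphenyl for a 4-hydroxyphenyl, on the other aromatic carbon of the core, is the step from compound 2 to compound 3, which stayed within the scatter. Going by the values given here, that is the only measured step bearing on this change, so no step beyond the scatter is expected in this assay in either direction.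

For compound 4 the expected value is 13000 nM, with a range of 5000 nM to 40000 nM. The step of a 1.1-fold lower number from compound 3 to compound 4 (0.04 log units; within the scatter) is thus expected to be small.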

Compound 4, half-maximal inhibitory concentration: > 50000 nM
Compound 4 ended at the assay's limit; the forecaster's own chance of this, stated with the estimate: 15%; middle value at least 3.8-fold (0.58 log units) away from the limit.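

The exchange of 3-hydroxyphenyl for 4-hydroxyphenyl does not have one fixed size in this assay: it depends on the group carried on the other side of the shared core. With a 3-hydroxyphenyl group there, the exchange gives a 1.1-fold lower number from compound 2 to compound 3 (0.05 log units; within the scatter), whereas with a 4-hydroxyphenyl group there, it gives an at least 3.4-fold higher number from compound 3 to compound 4 (0.54 log units; beyond the scatter). With 4-hydroxyphenyl held constant, compound 4 now also gives only a limit, so the 3-hydroxyphenyl group of compound 3 is the only one of the three hydroxyphenyl isomers at this position to give a number: the limit of > 50000 nM in this assay, at which 2 of the 4 values shown sit.

The step between the two limits cannot be read, so compound 1 and compound 4 remain unordered. Also open, going by these compounds, is whether a methoxyphenyl or aminophenyl group at this position would keep the value of compound 3.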